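The compounds below may be only part of what the source reports. "The series", "measured", "known", "first", "only" and "open" are said of these compounds alone.

Compound 3 `COC1=C(C)C(=O)/C(=C(O)/C=C/c2ccc(F)cc2)C(=O)C1(C)C` gives 3.7 ug/mL in a functional assay on KB cells (Homo sapiens) for cytotoxicity (on this read-out lower numbers stand for an effect already at smaller amounts and higher numbers for an effect only at larger amounts of compound), numerically the highest of the three numbers shown, though compound 1 `COC1=C(C)C(=O)/C(=C(O)/C=C/c2ccc(OC)cc2)C(=O)C1(C)C` with 3.6 ug/mL and compound 2 `COC1=C(C)C(=O)/C(=C(O)/C=C/c2cccc(OC)c2)C(=O)C1(C)C` with 3.3 ug/mL both lie within the scatter of it, as the steps of a 1.0-fold higher number from compound 1 to compound 3 (0.01 log units; within the scatter) and a 1.1-fold higher number from compound 2 to compound 3 (0.05 log units; within the scatter) make clear. Compound 4 `COC1=C(C)C(=O)/C(=C(O)/C=C/c2nccs2)C(=O)C1(C)C` differs from compound 3 by 1,3-thiazol-2-yl in place of 4-fluorophenyl on a double-bonded chain carbon bound to a double-bonded chain carbon. The changes on the aryl group seen so far, a 1.1-fold lower number from compound 1 to compound 2 (0.04 log units; within the scatter), a 1.0-fold higher number from compound 1 to compound 3 (0.01 log units; within the scatter) and a 1.1-fold higher number from compound 2 to compound 3 (0.05 log units; within the scatter), all stayed within the scatter, but none of them swaps the six-membered aromatic ring of carbon only for a five-membered aromatic ring with 2 hetero atoms, so they bear only loosely on this step. A step of a 1.1-fold higher number from compound 3 to compound 4 (0.03 log units; within the scatter) is therefore expected, not beyond the scatter. Compound 4 is estimated to give 4 ug/mL, with a range from 2 ug/mL to 8 ug/mL.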

Compound 4, concentration for half-maximal effect: 4.3 ug/mL
Compound 4: middle estimate off by 1.1-fold (0.03 log units), on the low side; the measured number falls inside the stated range.
By their numbers in this assay, from the lowest: compounds 2, 1, 3 and 4 (each within the scatter of the next).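

In this assay, replacing a six-membered aromatic ring of carbon only with the five-membered aromatic ring of 1,3-thiazol-2-yl stays within the scatter from each earlier compound (a 1.2-fold higher number from compound 3 to compound 4 (0.07 log units; within the scatter); a 1.3-fold higher number from compound 2 to compound 4 (0.11 log units; within the scatter); a 1.2-fold higher number from compound 1 to compound 4 (0.08 log units; within the scatter)). At this place, then, the read-out separates neither the ring type nor the substituents tried on the ring. Nothing measured here explains this flat result. On these data alone, whether an amine, a carboxylic acid or a longer alkyl chain in place of the aromatic ring would shift the number remains open.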